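A Fluorine Swap Repeated Across Two Cores

The compounds below may be only part of what the source reports. "The series", "measured", "known", "first", "only" and "open" are said of these compounds alone.

Compound 1 `Clc1ncnc2c1ncn2Cc1ccccc1` and compound 2 `Fc1ccc(Cn2cnc3c(Cl)ncnc32)cc1` share one core and differ in a single place: fluoro in place of hydrogen on an aromatic carbon. In an assay on isolated protein for inhibition of RAC-alpha serine/threonine-protein kinase (Homo sapiens), tested at 30 uM (on this read-out lower numbers stand for less inhibition and higher numbers for more inhibition at the one concentration tested (going by the name of the read-out)), compound 1 gives 0%, and compound 2 gives 0%, so that no change at the digits printed from compound 1 to compound 2 (within the scatter). Compound 3 `c1ccc(Cc2[nH]cnc3ncnc2-3)cc1` rests on a second core; the difference between the two cores is not broken down here. In this assay compound 3 gives 0%, level with compound 1 and compound 2. Compound 4 `Fc1ccc(Cc2[nH]cnc3ncnc2-3)cc1` is the not yet measured partner of compound 3, made by the same change, (fluoro in place of hydrogen on an aromatic carbon), at a place described in the same words. Compound 4 is therefore expected to give 0%, between -5% and 10%, because no change at the digits printed from compound 1 to compound 2 (within the scatter). The expected step is no change at the digits printed from compound 3 to compound 4 (within the scatter).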

Compound 4, a percentage reported as inhibition, at one concentration (the size of the read-out at that concentration, not a potency): 3%
Beside the measured number, compound 4's estimate is 3 percentage points below it; measured number inside the range.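

In this assay, the step on the second core is a number 3 percentage points higher from compound 3 to compound 4 (within the scatter), and it agrees with the step on the first core: the same change on two cores in this assay, no change at the digits printed (within the scatter) from compound 1 to compound 2 and a number 3 percentage points higher (within the scatter) from compound 3 to compound 4, 3 percentage points apart, within the scatter of two such steps. So far, fluoro in place of hydrogen on an aromatic carbon has left the read-out within the scatter on both cores. Among these compounds, this does not show that the change would carry over equally from core to core in a compound with clear inhibition, since these pairs show little or no inhibition at the one concentration tested and compound 4 gives only 3%.

The compounds shown leave open whether an amine or a carboxylic acid at the same place on the six-membered aromatic ring would give a read-out beyond the scatter on either core.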